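A few compounds are considered here, and "the series" means these few. Any claim that something is new, unique, unknown or untested is made for them only; others in the source may bear on it.

Compound 1 `C/C=C/C(=O)N(Cc1ccc(OC)c(N)c1)c1cc(OC)c(OC)c(OC)c1` and compound 2 `C/C=C/C(=O)N(Cc1ccc(OC)cc1)c1cc(OC)c(OC)c(OC)c1` share a core carrying a (prop-1-en-1-yl)carbonyl group on the ring nitrogen. In a functional assay on MGC-803 cells (Homo sapiens) for inhibition, read by MTT assay, with a stated time of 48 h (on this read-out higher numbers stand for weaker inhibition and lower numbers for stronger inhibition), compound 1 gives 150 nM, while compound 2 gives 450 nM. The difference between them, (amino in place of hydrogen on an aromatic carbon), gives a step of a 3.0-fold lower number from compound 2 to compound 1 (0.48 log units; beyond the scatter).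

Compound 3 `COc1ccc(CNc2cc(OC)c(OC)c(OC)c2)cc1` differs from compound 2 in its core: hydrogen in place of (prop-1-en-1-yl)carbonyl on a nitrogen on an aromatic ring. That change brings a step of a 25-fold higher number from compound 2 to compound 3 (1.40 log units; beyond the scatter), so in this assay compound 3 gives 11400 nM, the highest of the three numbers.

Compound 4 `COc1ccc(CNc2cc(OC)c(OC)c(OC)c2)cc1N` has not been measured. It differs from compound 3 by amino in place of hydrogen on an aromatic carbon, the same change that turns compound 2 into compound 1, at the same place on the ring. The step from compound 3 to compound 4 is therefore expected to be about a 2.5-fold lower number from compound 3 to compound 4 (0.40 log units; beyond the scatter), set beside the measured 3.0-fold lower number from compound 2 to compound 1 (0.48 log units; beyond the scatter), with a wider range allowed since the change is only seen once, on a different core. On that basis compound 4 is estimated to give 4500 nM in this assay, expected between 1500 nM and 14000 nM.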

Compound 4, half-maximal inhibitory concentration: 7970 nM
For compound 4 the middle estimate is 1.8-fold (0.25 log units) below the measured one, and the stated range covers the measured number.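

Adding the amino group gives a 1.4-fold lower number from compound 3 to compound 4 (0.16 log units; within the scatter) in this assay, a step that cannot be told from repeat-measurement noise on its own, yet it does not differ reliably from the step seen on the other core: the same change on two cores in this assay, a 3.0-fold lower number (0.48 log units; beyond the scatter) from compound 2 to compound 1 and a 1.4-fold lower number (0.16 log units; within the scatter) from compound 3 to compound 4, 2.1-fold (0.32 log units) apart, within the scatter of two such steps. Replacing the (prop-1-en-1-yl)carbonyl group with hydrogen gives a 53-fold higher number from compound 1 to compound 4 (1.73 log units; beyond the scatter), and this large weakening carries over between the two cores with the amino group present or absent: the same change on two cores in this assay, a 25-fold higher number (1.40 log units; beyond the scatter) from compound 2 to compound 3 and a 53-fold higher number (1.73 log units; beyond the scatter) from compound 1 to compound 4, 2.1-fold (0.32 log units) apart, within the scatter of two such steps. These pairs show that both changes behaved consistently within the scatter across these two cores, but they do not show that the amino group gives a real gain on the core of compound 3, or that either step would hold on any other core.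

The compounds shown leave open what a different group on that aromatic carbon, such as a hydroxy or a dimethylamino group, would do. They also leave open whether a longer chain or a saturated propyl chain on the carbonyl would keep the inhibition.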